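The source may report more compounds than this note shows. Statements on the series, on what has been measured and on what is new or still open speak of the compounds shown alone.

Measured compounds:

compound 1, `CCC(C)NC(=C\C(=O)/C=C/c1ccc(O)c(OC)c1)/C=C/c1ccc(O)c(OC)c1`: > 25000 nM
compound 2, `COc1cc(/C=C/C(=O)/C=C(/C=C/c2ccc(O)c(OC)c2)NC2CCCCC2)ccc1O`: 24700 nM
compound 3, `CCC(C)NC(=C\C(=O)/C=C/c1ccc(O)cc1)/C=C/c1ccc(O)cc1`: 13100 nM

Notes on the series in a functional assay on CHO-K1 cells (Cricetulus griseus) for inhibition, read by MTT assay, with a stated time of 72 h; a higher number here means a weaker inhibitor, a lower number a stronger inhibitor. For compound 1 the value > 25000 nM is a limit of the assay, not a number; it sits at the limit of > 25000 nM in this assay, at which 1 of the 3 values shown sits. Compound 2 differs from compound 1 by cyclohexyl in place of sec-butyl on an amine nitrogen. In this assay compound 2 gives 24700 nM. The step is an at least 1.0-fold lower number from compound 1 to compound 2 (0.00 log units; that floor lies within the scatter), which reaches only the floor set by the limit and stays within the scatter, so no direction is claimed for it. Compound 3 carries a different core; how the core of compound 3 differs from the core of compound 1 is not broken down here. In this assay compound 3 gives 13100 nM, which lies within the scatter of the value of compound 2.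

The unmeasured compound 4, `O=C(/C=C(/C=C/c1ccc(O)cc1)NC1CCCCC1)/C=C/c1ccc(O)cc1`, differs from compound 3 by cyclohexyl in place of sec-butyl on an amine nitrogen. The place of this change reads word for word as for the pair of compound 1 and compound 2, so it is the same change made on the core of compound 3. Since that earlier step, an at least 1.0-fold lower number from compound 1 to compound 2 (0.00 log units; that floor lies within the scatter), showed no movement beyond the floor of the limit, the expected step for compound 4 is likewise flat, a 1.0-fold lower number from compound 3 to compound 4 (0.02 log units; within the scatter). Compound 4 is therefore expected to give about 12500 nM in this assay, with an expected range from 6000 nM to 25000 nM; this rests on compound 3 at 13100 nM and on the size of the step of an at least 1.0-fold lower number from compound 1 to compound 2 (0.00 log units; that floor lies within the scatter).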

Compound 4, half-maximal inhibitory concentration: 9200 nM
Estimate against measurement, compound 4: 1.4-fold (0.13 log units) above, within the range that was stated.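

In this assay, cyclohexyl in place of sec-butyl on the amine nitrogen of the core of compound 3 gives a 1.4-fold lower number from compound 3 to compound 4 (0.15 log units; within the scatter), so on this core the change moves the number by no more than the usual scatter of repeated measurements. For compound 1 the value > 25000 nM is a limit of the assay, not a number. The result therefore shows a flat step on one core only; it neither confirms that the step carries over from the core of compound 1 nor shows that the two cores respond differently: the same change on two cores in this assay, an at least 1.0-fold lower number (0.00 log units; that floor lies within the scatter) from compound 1 to compound 2 and a 1.4-fold lower number (0.15 log units; within the scatter) from compound 3 to compound 4; the limit leaves it open whether they differ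

The compounds shown carry only sec-butyl and cyclohexyl on the amine nitrogen, so it remains open whether another group there, such as methyl, benzyl or a longer chain, would give a step beyond the scatter. On these data alone, it also remains open whether the same change would stay flat on a core with another group in place of the hydroxyl, such as an amine or a carboxylic acid.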